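Pyridine to methyltriazole on the aminomethyl arm

This account rests on a few compounds, and the source may have more. Where it says the series, first, only, none or still open, it means among the compounds named here.

Compound 1 `Cc1cc(NCc2cccnc2)n2nc(C)c(-c3ccccc3)c2n1`: 110000 nM
Compound 2 `Cc1cc(NCc2ccccn2)n2ncc(-c3ccccc3F)c2n1`: 5000 nM

Going by the values given here, in a physicochemical assay for solubility, read by HPLC, using the shake flask method, measured as kinetic solubility, with a stated time of 2 h, at pH 7.4 (on this read-out lower numbers stand for lower solubility and higher numbers for higher solubility), compound 1 gives 110000 nM, the higher of the two numbers recorded; compound 2 gives 5000 nM, and the two differ in more than one place, so no single step connects them. Compound 3 `Cc1cc(NCc2ncnn2C)n2nc(C)c(-c3ccccc3)c2n1` has not yet been measured. Compound 3 differs from compound 1 by one change: 1-methyl-1H-1,2,4-triazol-5-yl in place of pyridin-3-yl on a saturated chain carbon bound to a nitrogen on an aromatic ring. Among the compounds with values here, nothing measured so far traces this particular change, so the expected step from compound 1 to compound 3 in this assay, a 1.3-fold higher number from compound 1 to compound 3 (0.10 log units; within the scatter), is small and within the scatter, leaning slightly upward. Compound 3 is therefore expected to give about 140000 nM, within a range of 45000 nM to 400000 nM.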

Compound 3, solubility: 185000 nM
The estimate for compound 3 lay 1.3-fold (0.12 log units) below the measured number; measured number inside the range.
By their numbers in this assay, from the lowest: compound 2; then compounds 1 and 3 (each within the scatter of the next).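

In this assay, 1-methyl-1H-1,2,4-triazol-5-yl in place of pyridin-3-yl on a saturated chain carbon bound to a nitrogen on an aromatic ring gives a 1.7-fold higher number from compound 1 to compound 3 (0.23 log units; within the scatter). On the core of compound 1, this position therefore takes a five-membered aromatic ring with 3 hetero atoms without a step beyond the scatter, something compounds 1 and 2, which differ in more than one place, could not show. No measured evidence bears on this result.

Going by these compounds, whether a morpholine or a carboxylic acid at this position would also stay within the scatter of compound 1 remains open. So does whether the same exchange reads alike on the core of compound 2.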